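Fluoro to methoxy at a cytotoxicity limit

A few compounds are considered here, and "the series" means these few. Any claim that something is new, unique, unknown or untested is made for them only; others in the source may bear on it.

compound 1 `Cc1ccc(C2=NN(c3nc(-c4ccc(F)cc4)cs3)C(c3ccc(F)cc3)C2)s1`: > 500 ug/mL
compound 2 `CS(=O)(=O)c1ccc(-c2csc(N3N=C(c4ccc(Cl)s4)CC3c3ccc(F)cc3)n2)cc1`: > 500 ug/mL

In an ADME assay on NIH3T3 cells (Mus musculus) for cytotoxicity, read by XTT assay, with a stated time of 24 h (on this read-out lower numbers stand for stronger inhibition and higher numbers for weaker inhibition), compound 1 gives > 500 ug/mL, which is a limit of the assay and not a number. Compound 2 gives > 500 ug/mL, also a limit. The record so far is thus (the limit of > 500 ug/mL in this assay, at which 2 of the 2 values shown sit).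

Compound 3 `COc1ccc(-c2csc(N3N=C(c4ccc(C)s4)CC3c3ccc(F)cc3)n2)cc1` has not yet been measured. It keeps the core of compound 1 and changes one group, with methoxy in place of fluoro on an aromatic carbon, para to a large group (methoxy in place of fluoro on an aromatic carbon). For the measured compounds named here, no measured pair shows what this swap does. The step of a number no higher from compound 1 to compound 3 (the limit leaves the size open) is therefore expected to stay within the usual scatter, in no particular direction. That expectation leans on compound 1, whose reading of > 500 ug/mL is a limit. For compound 3 the estimated value is 500 ug/mL, with an expected range from 200 ug/mL to 1000 ug/mL. Another report of only a limit is likely.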

Compound 3, half-maximal inhibitory concentration: 147 ug/mL
For compound 3 the middle estimate is 3.4-fold (0.53 log units) above the measured one, outside the stated range (below it).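

Before this result, no reading in this assay gave an actual number, so nothing showed whether the group at this place could change the read-out at all: the limit of > 500 ug/mL in this assay, at which 2 of the 3 values shown sit.

Compound 1 gives > 500 ug/mL, which is a limit of the assay and not a number. Methoxy in place of fluoro, on an aromatic carbon para to a large group, now produces an at least 3.4-fold lower number from compound 1 to compound 3 (0.53 log units; beyond the scatter), so this position can move the read-out, although the true size of the step stays unknown.

A single pair cannot tell whether methoxy itself matters or whether the loss of fluoro is enough. It also leaves open what other groups at this place, such as a hydroxyl, an amine or a longer ether chain, would do, and whether the same swap would act alike in a different compound.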